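Rearranging one side chain of compound 1

A few compounds are considered here, and "the series" means these few. Any claim that something is new, unique, unknown or untested is made for them only; others in the source may bear on it.

In a functional assay (lung) for inhibition, with Cavia porcellus as the target (a lower number here means a stronger inhibitor, a higher number a weaker inhibitor), compound 1 `CC(CCCC(=O)O)c1cccc(OCc2ccc3ccccc3n2)c1` gives 500 nM. Within the data shown here, that is the higher of the two numbers known so far, since compound 2 `O=C(O)CC1CCC(c2ccc(OCc3ccc4ccccc4n3)cc2)C1` gives 22 nM, a clearly stronger result. Compound 3 `CC(CCCc1cccc(OCc2ccc3ccccc3n2)c1)C(=O)O` has the same atoms as compound 1, joined differently: 4-carboxypentyl in place of 4-carboxy-1-methylbutyl on an aromatic carbon. In words, 4-carboxypentyl stands in place of 4-carboxy-1-methylbutyl on an aromatic carbon, while the rest of the core of compound 1 stays the same. Among the measured compounds shown here, no measured pair of compounds shows what a change of this kind does. In this assay, the expectation is therefore a small step towards a lower number, not beyond the usual scatter, with a wide margin of doubt in both directions. The expected step is a 1.4-fold lower number from compound 1 to compound 3 (0.15 log units; within the scatter). For compound 3 the estimated value is 350 nM, within a range of 80 nM to 1500 nM.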

Compound 3, half-maximal inhibitory concentration: 75 nM
Compound 3: the middle estimate sits 4.7-fold (0.67 log units) above what was measured; the measured number lies below the stated range.
By their numbers in this assay, from the lowest: compound 2; then compound 3; then compound 1.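

Within this assay, the side chain on this aromatic carbon proves sensitive to how its atoms are joined: 4-carboxypentyl in place of 4-carboxy-1-methylbutyl gives a 6.7-fold lower number from compound 1 to compound 3 (0.82 log units; beyond the scatter). The two groups match in everything counted for them, including heavy atoms, double bonds, hydrogen-bond donors and acceptors, and net charge, so those counts alone do not separate the two results. Nothing measured on these compounds explains the difference.

This is a single pair in a single assay, so it cannot show whether the same rearrangement would have a similar effect on another core. It also leaves open how a longer chain without the methyl branch, or an amide in place of the carboxylic acid, would behave at this position.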